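The compounds below may be only part of what the source reports. "The series", "measured", "known", "first", "only" and "open" are said of these compounds alone.

Compound 1 `COc1cc(OC)c(OC)cc1/C=C/COC(=O)/C=C/c1ccc(Br)cc1`: 25%
Compound 2 `COc1cccc(/C=C/C(=O)OC/C=C/c2cc(OC)c(OC)cc2OC)c1`: 50%

In a functional assay on the whole organism (strain Kunming) with Mus musculus as the target, with a stated time of 0.5 h, at a dose of 300 mg/kg by the intraperitoneal route (on this read-out higher numbers stand for a weaker effect at the one dose given and lower numbers for a stronger effect), compound 2 gives 50%, the highest of the two numbers in hand. Its nearest neighbour is compound 1, which in this assay gives 25%; the step of a number 25 percentage points higher from compound 1 to compound 2 (beyond the scatter) lies beyond the scatter and is of modest size.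

Compound 3 `COc1cc(OC)c(OC)cc1/C=C/COC(=O)/C=C/c1ccc(Cl)cc1` has not yet been measured in this assay. It differs from compound 2 in one place: 4-chlorophenyl in place of 3-methoxyphenyl on a double-bonded chain carbon bound to a double-bonded chain carbon. Going by the values given here, the one measured step that bears on this change is a number 25 percentage points higher from compound 1 to compound 2 (beyond the scatter), in which 3-methoxyphenyl replaced 4-bromophenyl at the same place. The change to compound 3 removes that 3-methoxyphenyl again, and compound 3 carries 4-chlorophenyl where compound 1 carries 4-bromophenyl. Since the number rose when 3-methoxyphenyl entered, a fall of comparable size is expected when it leaves, with compound 3 estimated to land nearer compound 1 than compound 2. The expected step is a number 20 percentage points lower from compound 2 to compound 3 (beyond the scatter), downward and beyond the scatter. Compound 3 is therefore estimated at 30% in this assay, within the range 15% to 50%.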

Compound 3, a percentage reported as activity, at one dose (the size of the read-out at that dose, not a potency): 25%
For compound 3 the middle estimate is 5 percentage points above the measured one, within the range that was stated.
By their numbers in this assay, from the lowest: compounds 1 and 3 (each within the scatter of the next); then compound 2.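

In this assay, the step of a number 25 percentage points lower from compound 2 to compound 3 (beyond the scatter) shows that the higher number seen with 3-methoxyphenyl on a double-bonded chain carbon bound to a double-bonded chain carbon does not persist when 4-chlorophenyl stands there instead. The step of no change at the digits printed from compound 1 to compound 3 (within the scatter) adds what the first pair could not show: with chloro in place of bromo on an aromatic carbon, the read-out does not separate the two compounds, so the lower number is not confined to the bromo compound. Among these three compounds, the one carrying 3-methoxyphenyl is therefore the only one that stands apart, with steps beyond the scatter to both halogen-bearing compounds, which in turn cannot be told apart.

The compounds shown leave open whether the higher number follows the methoxy group itself or the place it holds on the phenyl ring, and how unsubstituted phenyl, 4-methoxyphenyl or 4-aminophenyl would read at this position. No supporting measurement is at hand to explain why the number moves with this change.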